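The compounds below may be only part of what the source reports. "The series", "measured", "known", "first", "only" and "open" are said of these compounds alone.

Compound 1 `COc1ccc(/C=C/c2ccc3ccccc3c2)cc1`: > 5000 nM
Compound 2 `COc1cccc(/C=C\c2ccc3ccccc3c2)c1`: 1920 nM
Compound 3 `COc1ccc(/C=C/c2ccc3ccccc3c2)cc1F`: > 5000 nM

The three compounds were tested in a functional assay on HCT-116 cells (Homo sapiens) for inhibition; a lower number here means a stronger inhibitor, a higher number a weaker inhibitor. The value of compound 1 is only a limit of the assay. The value of compound 3 is likewise only a limit, so both sit at the limit of > 5000 nM in this assay, at which 2 of the 3 values shown sit. The step that the two limits leave unreadable from compound 1 to compound 3 therefore cannot be read; it is the change (fluoro in place of hydrogen on an aromatic carbon). Among the compounds with values here, compound 2 gives the only number; how its core differs from that of compound 1 is not broken down here.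

Compound 4 `COc1cc(/C=C\c2ccc3ccccc3c2)ccc1F` is not yet measured. It differs from compound 2 by fluoro in place of hydrogen on an aromatic carbon, the same kind of change as from compound 1 to compound 3, but made para rather than meta to the large group. Since the measured step of this kind is unreadable, the step of a 1.3-fold higher number from compound 2 to compound 4 (0.11 log units; within the scatter) is expected to be small, resting on compound 2 at 1920 nM. Compound 4 is estimated at 2500 nM, between 800 nM and 6000 nM.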

Compound 4, half-maximal inhibitory concentration: 450 nM
Beside the measured number, compound 4's estimate is 5.6-fold (0.74 log units) above it, and the stated range ends above it.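

In this assay, fluoro in place of hydrogen on an aromatic carbon gives a 4.3-fold lower number from compound 2 to compound 4 (0.63 log units; beyond the scatter), so on the core of compound 2 this change, ortho to a methoxy group and para to a large group, has a real effect. This does not show that the change carries over from one core to another, since the fluoro sits at a different place in compound 3. The step from compound 1 to compound 3 cannot be read, as both values are only limits of the assay: the limit of > 5000 nM in this assay, at which 2 of the 4 values shown sit.

The compounds shown leave open whether a chloro or an amine at the same place on the core of compound 2 would give a similar step. They also leave open whether fluoro at this place would lift the core of compound 1 clear of the limit.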